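Removing the halogens from the hydrazone aryl group

The source may report more compounds than this note shows. Statements on the series, on what has been measured and on what is new or still open speak of the compounds shown alone.

In a functional assay on A549 cells (Homo sapiens) for antiproliferative activity, read by MTT assay (a lower number here means a stronger inhibitor, a higher number a weaker inhibitor), compound 1 `Cn1c(=O)c(=O)n(C2CCCC2)c2nc(N/N=C/c3ccc(O)cc3)ncc21` reads > 100000 nM as a limit of the assay, not a number. Compound 2 `Cn1c(=O)c(=O)n(C2CCCC2)c2nc(N/N=C/c3ccco3)ncc21` also reads > 100000 nM as a limit of the assay. Compound 3 `Cn1c(=O)c(=O)n(C2CCCC2)c2nc(N/N=C/c3ccc(F)cc3Cl)ncc21` stands alone with a true number, 11000 nM in this assay. Its standing is judged against compound 1 and compound 2.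

Compound 4 `Cn1c(=O)c(=O)n(C2CCCC2)c2nc(N/N=C/c3cccc(O)c3)ncc21` replaces the group in compound 3 on the carbon with a double bond to nitrogen: 3-hydroxyphenyl in place of 2-chloro-4-fluorophenyl on a carbon with a double bond to nitrogen is the change, 3-hydroxyphenyl in place of 2-chloro-4-fluorophenyl.

Among the measured compounds shown here, three measured steps bear on it. The data show an at least 9.0-fold lower number from compound 1 to compound 3 (0.95 log units; beyond the scatter) when 2-chloro-4-fluorophenyl replaces 4-hydroxyphenyl, and an at least 9.0-fold lower number from compound 2 to compound 3 (0.95 log units; beyond the scatter) when it replaces furan-2-yl. Both sizes are floors that rest on the limit of > 100000 nM in this assay, at which 2 of the 3 values shown sit, in the data. The third, a step that the two limits leave unreadable from compound 1 to compound 2 in the data, adds nothing on size.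

Compound 4 carries a hydroxyphenyl, as compound 1 does, so an at least 9.0-fold lower number from compound 1 to compound 3 (0.95 log units; beyond the scatter) is the nearest guide when read in reverse. Expected in this assay is a 5.5-fold higher number from compound 3 to compound 4 (0.74 log units; beyond the scatter) by this estimate, a clear move toward weaker inhibition. For compound 4 the estimated value is 60000 nM with an expected range from 20000 nM to 150000 nM in this assay, and a report of only a limit would be no surprise.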

Compound 4, half-maximal inhibitory concentration: > 100000 nM
Compound 4: a limit, no number; the forecaster's own chance of this, stated with the estimate: 50%; at least 1.6-fold (0.22 log units) between middle value and limit.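

Read in this assay, an at least 9.0-fold higher number from compound 3 to compound 4 (0.95 log units; beyond the scatter), so the single true number in this series is lost when 3-hydroxyphenyl takes the place of 2-chloro-4-fluorophenyl on the carbon with a double bond to nitrogen. Compound 1 had already shown this for 4-hydroxyphenyl, and compound 4 extends it to a second hydroxyphenyl, so that among the four compounds shown only the halogen-bearing 2-chloro-4-fluorophenyl gives a true number at this place, and none goes against that. The steps from compound 1 and from compound 2 to compound 4 cannot be read, so nothing can be said about any order among these three, including between the two hydroxyphenyl groups: the limit of > 100000 nM in this assay, at which 3 of the 4 values shown sit.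

The compounds shown leave open whether the chlorine or the fluorine alone would keep a true number, as 2-chlorophenyl or 4-fluorophenyl at this place would tell. They also leave open whether a halogen is needed at all, or whether a ring bearing a methyl or a methoxy group would read in the same range as compound 3.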